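The compounds below may be only part of what the source reports. "The series", "measured", "known", "first", "only" and "open" are said of these compounds alone.

Working notes on the series. Among the compounds with values here, compound 1 `C=CC[N+](C)(C)c1cccc(O)c1` is the only member with a numerical read-out: in a functional assay with Cavia porcellus as the target (a higher number here means a weaker inhibitor, a lower number a stronger inhibitor), compound 1 gives 13000 nM. Compound 2 `C=CC[N+](C)(C)c1cccc(OC)c1` differs from compound 1 by methyl in place of hydrogen on an oxygen on an aromatic ring. In this assay compound 2 gives only a limit, > 3000 nM. The resulting step, a step that the limit leaves unreadable from compound 1 to compound 2, cannot be sized because of the limit of > 3000 nM in this assay, at which 2 of the 3 values shown sit. Compound 3 `C[N+](C)(Cc1ccccc1)c1ccc(O)cc1` sits on a second core; the difference between the two cores is not broken down here. In this assay compound 3 also gives only a limit, > 3000 nM. Within the data shown here, compound 4 `COc1ccc([N+](C)(C)Cc2ccccc2)cc1` remains to be measured; it differs from compound 3 by methyl in place of hydrogen on an oxygen on an aromatic ring, the same change at the same place as the one made between compound 1 and compound 2, so the two pairs are directly comparable once both are read. Since the measured counterpart of this change gave no readable size, the expectation for compound 4 rests on its parent alone and is held loosely. The step is expected to be a step that the limit leaves unreadable from compound 3 to compound 4. Compound 4 is expected to give 20000 nM, within 5000 nM to 80000 nM, most likely reported again as a limit.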

Compound 4, half-maximal inhibitory concentration: > 3000 nM
Compound 4 was reported as a limit; the forecaster's own chance of this, stated with the estimate: 70%; the middle value does not contradict the limit.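

In this assay, within the data shown here, no size can be read for the step between compound 3 and compound 4, and the pair adds no new step to the series: the limit of > 3000 nM in this assay, at which 3 of the 4 values shown sit. The compounds shown leave open how large the change from hydroxy to methoxy is on either core.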